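The compounds below may be only part of what the source reports. "The series", "measured", "known", "first", "only" and "open" are said of these compounds alone.

In an ADME assay on 697 cells (Homo sapiens) for cytotoxicity, with a stated time of 48 h (a lower number here means a stronger inhibitor, a higher number a weaker inhibitor), three compounds have been measured. Compound 1 `O=C(NO)c1cc(F)c(Cn2nnc(-c3ccco3)n2)c(F)c1` gives > 1000 nM, which is a limit and not a number. Compound 3 `O=C(NO)c1cc(F)c(Cc2nnc(-c3ccncc3)s2)c(F)c1` gives > 1000 nM, again a limit. Compound 2 `Cn1c(Sc2c(F)cc(C(=O)NO)cc2F)nnc1-c1cccnn1` gives > 1000 nM, also a limit, so it has no exact position on the scale. Together the three results show (the limit of > 1000 nM in this assay, at which 3 of the 3 values shown sit).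

Compound 4 `Cc1cc(-c2nnc(Sc3c(F)cc(C(=O)NO)cc3F)n2C)nn1C` differs from compound 2 in one place, on an aromatic carbon of a five-membered aromatic ring with 3 nitrogen, where 1,5-dimethyl-1H-pyrazol-3-yl stands in place of pyridazin-3-yl: 1,5-dimethyl-1H-pyrazol-3-yl in place of pyridazin-3-yl on an aromatic carbon. Among the compounds with values here, no pair of measured compounds differs in one place, so the data offer no step to compare. No change beyond the usual scatter of this assay is expected, in either direction. The expected change is a step that the limit leaves unreadable from compound 2 to compound 4, and it is estimated from a limit rather than a number. Compound 4 is estimated at 2000 nM, with an expected range of 1000 nM to 6000 nM.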

Compound 4, half-maximal inhibitory concentration: > 1000 nM
Compound 4: only a limit was reported; the forecaster's own chance of this, stated with the estimate: 85%; the middle value does not contradict the limit.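

Compound 2 and compound 4 each carry only a limit in this assay, so the step from pyridazin-3-yl to 1,5-dimethyl-1H-pyrazol-3-yl cannot be read. The compounds shown leave open where any of them lies on the scale, and whether any group changes the result: the limit of > 1000 nM in this assay, at which 4 of the 4 values shown sit.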